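This account rests on a few compounds, and the source may have more. Where it says the series, first, only, none or still open, it means among the compounds named here.

Working notes on the series. Compound 1 `C=CCN1C(=O)C(CC(=O)c2ccc(F)cc2)S/C1=N\N=C1\CC2CCC1(C)C2(C)C`, compound 2 `O=C(CC1S/C(=N\N=C\c2c(-c3ccccc3)[nH]c3ccccc23)NC1=O)c1ccccc1` and compound 3 `O=C1N/C(=N/N=C/c2c(-c3ccc(Cl)cc3)[nH]c3ccccc23)SC1CCO` have been run in an ADME assay on BJ cells (Homo sapiens) for cytotoxicity, read by fluorescence, with a stated time of 24 h; a lower number here means a stronger inhibitor, a higher number a weaker inhibitor. In this assay compound 1 returns only a limit, > 50000 nM. In this assay compound 2 likewise returns only a limit, > 50000 nM. Among the compounds with values here, compound 3 is the one member that yields a figure in this assay, 22400 nM. Compound 2 therefore stands at the upper edge of what the measurements show: the limit of > 50000 nM in this assay, at which 2 of the 3 values shown sit, and the one figure, from compound 3, sits not far from that edge. Within the data shown here, no pair of measured compounds differing in a single place is available, so no measured step sets a scale for the effect of a side-chain change.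

Compound 4 `CCC1S/C(=N\N=C\c2c(-c3ccccc3)[nH]c3ccccc23)NC1=O` has not been measured in this assay. It is related to compound 2 by one change: methyl in place of benzoyl on a saturated chain carbon bound to a saturated ring carbon. The change takes out one six-membered aromatic ring of carbon only and one hydrogen-bond acceptor and leaves a methyl at the same place.

With compound 2 at the limit, the expected step, a step that the limit leaves unreadable from compound 2 to compound 4, is none beyond the scatter. Compound 4 is estimated at 60000 nM in this assay, within 25000 nM to 150000 nM, and is expected most likely to be reported again only as a limit.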

Compound 4, half-maximal inhibitory concentration: > 50000 nM
Compound 4: no number, only a limit (the forecaster's own chance of this, stated with the estimate: 80%); the middle value lies beyond the limit too.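

In this assay, within the data shown here, compound 2 and compound 4 both return only limits, so no step between them can be read. The compounds shown leave open whether methyl in place of benzoyl on a saturated chain carbon bound to a saturated ring carbon changes the result in this assay at all, and how far either compound lies beyond its limit.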